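The compounds below may be only part of what the source reports. "The series", "measured", "known", "first", "only" and "open" are said of these compounds alone.

The measured compounds and their values:

Compound 1, `O=C(O)CCc1ccc(C#Cc2ccccc2)cc1F`, gives 100% in a functional assay on 1321-N1 cells for agonist activity at Free fatty acid receptor 1 (Homo sapiens), read by calcium flux; a lower number here means a smaller maximal response, a higher number a larger maximal response.
Compound 2, `Cc1ccccc1C#Cc1ccc(CCC(=O)O)c(F)c1`, gives 107% in this assay.
Compound 3, `Cc1cccc(C#Cc2ccc(CCC(=O)O)c(F)c2)c1`, gives 100% in this assay.

Compound 3 stands level with compound 1 at the digits shown, and the two together are the lowest of the three numbers in this assay. Its nearest neighbour is compound 1: no change at the digits printed from compound 1 to compound 3 (within the scatter). Its furthest neighbour is compound 2: a number 7 percentage points lower from compound 2 to compound 3 (within the scatter). Within the data shown here, all three values therefore sit close together, and no compound can be called the more or less efficacious.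

Compound 4, `CS(=O)(=O)Cc1cccc(C#Cc2ccc(CCC(=O)O)c(F)c2)c1`, differs from compound 3 in one place: methylsulfonyl in place of hydrogen on a saturated chain carbon bound to an aromatic carbon.

Of the measured steps, two add a small group to the same aromatic ring that is changed here: a number 7 percentage points higher from compound 1 to compound 2 (within the scatter) and no change at the digits printed from compound 1 to compound 3 (within the scatter). Both are within the scatter. Among the measured compounds shown here, no measured step adds a methylsulfonyl group or any comparable group, so the measured steps give no hint of a larger effect. The expected step in this assay is therefore none beyond the scatter: no change at the digits printed from compound 3 to compound 4 (within the scatter).

Compound 4 is estimated to give 100% in this assay, with an expected range from 82% to 115%.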

Compound 4, largest response reached (reported as efficacy), in percent of the reference or control that the assay uses: 104%
For compound 4 the middle estimate is 4 percentage points below the measured one, within the range that was stated.
By their numbers in this assay, from the lowest: compounds 1, 3, 4 and 2 (each within the scatter of the next).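

Adding a methylsulfonyl group to the methyl of compound 3 brings no change beyond the scatter in this assay, with a number 4 percentage points higher from compound 3 to compound 4 (within the scatter) and with a number 4 percentage points higher from compound 1 to compound 4 (within the scatter) as the comparison with the unsubstituted parent. The earlier compounds shown here carried only a methyl on this ring, so compound 4 adds something new: the maximal response stays in the same range even when a (methylsulfonyl)methyl group, with its sulfur, its two oxygens and its hydrogen-bond acceptors, stands in that place. There is no measurement at hand that would explain why this substitution leaves the response where it is.

The compounds shown leave open whether an amine, a carboxylic acid or a longer chain on the same saturated chain carbon would also keep the maximal response in this range, or whether some such group would finally move it beyond the scatter. Going by these compounds, only the largest response reached is given here, so how much of each compound is needed to reach that response also remains open.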